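Changing the substituent on the ring oxygen

The compounds below may be only part of what the source reports. "The series", "measured", "known", "first", "only" and "open" are said of these compounds alone.

In a functional assay on A549 cells (Homo sapiens) for antiproliferative activity, read by MTT assay, with a stated time of 48 h (on this read-out lower numbers stand for stronger inhibition and higher numbers for weaker inhibition), compound 1 `COc1cc(-c2nnc3c(OCC(F)(F)F)cc(-c4ccc5[nH]ccc5c4)cn23)cc(OC)c1OC` gives 585 nM and compound 2 `COc1cc(-c2nnc3c(OCC(F)(F)F)cc(-c4ccc5c(ccn5C)c4)cn23)cc(OC)c1OC` gives 614 nM. Among the measured compounds shown here, compound 2 therefore stands level with the only other measured compound, and the two values lie within the scatter of each other.

Compound 3 `CCCN1CC(Oc2cc(-c3ccc4c(ccn4C)c3)cn3c(-c4cc(OC)c(OC)c(OC)c4)nnc23)C1` carries 1-propylazetidin-3-yl in place of 2,2,2-trifluoroethyl on an oxygen on an aromatic ring.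

For the measured compounds named here, the sole measured step, a 1.0-fold higher number from compound 1 to compound 2 (0.02 log units; within the scatter), is methyl in place of hydrogen on an aromatic nitrogen. It is a different change and offers no direct guide here. Going by the values given here, no measured compound varies the oxygen substituent, so the data favour no direction in this assay. The expected step is a 1.0-fold lower number from compound 2 to compound 3 (0.01 log units; within the scatter), which is none beyond the scatter, though with wide uncertainty. The estimate for compound 3 is 600 nM, with an expected range of 150 nM to 2500 nM.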

Compound 3, half-maximal inhibitory concentration: 234 nM
Estimate against measurement, compound 3: 2.6-fold (0.41 log units) above; low and high end bracket the measured number.
By their numbers in this assay, from the lowest: compound 3; then compounds 1 and 2 (each within the scatter of the next).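

Among the compounds shown here, the oxygen substituent is the first place where a single change moves the number beyond the scatter: in this assay, 1-propylazetidin-3-yl in place of 2,2,2-trifluoroethyl gives a 2.6-fold lower number from compound 2 to compound 3 (0.42 log units; beyond the scatter), whereas methyl on the aromatic nitrogen gave only a 1.0-fold higher number from compound 1 to compound 2 (0.02 log units; within the scatter). The position therefore tolerates the exchange of a fluorinated open chain for a four-membered non-aromatic ring carrying a nitrogen, with a gain rather than a loss in inhibition. No measurement at hand accounts for this step.

The compounds shown do not separate the contribution of the four-membered ring from that of its propyl chain or its nitrogen. From the compounds shown here alone, it remains open how an open-chain amine, a carboxylic acid or a longer chain on the ring nitrogen would read at this oxygen, and whether the same exchange holds on compound 1.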